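The compounds below may be only part of what the source reports. "The series", "measured", "known", "first", "only" and "open" are said of these compounds alone.

Measured so far:
- compound 1 `CCOC(=O)C1=C(C)NC(C)=C(C(=O)OCC)C1c1ccc(OCC(=O)NCc2ccccc2)cc1`: 8.9%
- compound 2 `CCOC(=O)C1=C(C)NC(C)=C(C(=O)OCC)C1c1ccc(OCC(=O)NNC(=O)c2ccc(C)cc2)cc1`: 46.7%
- compound 3 `CCOC(=O)C1=C(C)NC(C)=C(C(=O)OCC)C1c1ccc(OCc2nnc(S)o2)cc1`: 61.7%

In a functional assay on the whole organism (strain Wistar) for inhibition, with Rattus norvegicus as the target, read by paw edema, with stated times of 30 min and 2 h, at a dose of 20 mg/kg (a lower number here means less inhibition, a higher number more inhibition at the dose given (going by the name of the read-out)), compound 3 stands highest of the three, with compound 2 nearest, its value lower by a gap beyond the scatter, and compound 1 furthest behind. The next compound, compound 4 `CCOC(=O)C1=C(C)NC(C)=C(C(=O)OCC)C1c1ccc(OCC(=O)n2nc(C)cc2C)cc1`, keeps the shared core and alters only the side chain of compound 3: (3,5-dimethyl-1H-pyrazol-1-yl)carbonyl in place of 5-sulfanyl-1,3,4-oxadiazol-2-yl on a saturated chain carbon bound to an oxygen on an aromatic ring. For the measured compounds named here, two measured steps bear on this. The change a number 52.8 percentage points higher from compound 1 to compound 3 (beyond the scatter) shows how strongly the sulfanyl-oxadiazole lifts the number above the benzyl amide of compound 1, and a number 37.8 percentage points higher from compound 1 to compound 2 (beyond the scatter) shows that a carbonyl-bearing chain can also reach a high value, though not as high as compound 3. Since compound 4 gives up the sulfanyl-oxadiazole for a carbonyl-bearing group closer in kind to compounds 1 and 2, a downward step is expected, estimated as a number 26.7 percentage points lower from compound 3 to compound 4 (beyond the scatter). Compound 4 is therefore expected to give about 35%, within a range from 10% to 58%.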

Compound 4, a percentage reported as inhibition, in the whole organism at one dose (the size of the read-out at that dose, not a potency): 46.1%
Beside the measured number, compound 4's estimate is 11.1 percentage points below it, and the stated range covers the measured number.
By their numbers in this assay, from the lowest: compound 1; then compounds 4 and 2 (each within the scatter of the next); then compound 3.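

In this assay, the 5-sulfanyl-1,3,4-oxadiazol-2-yl group keeps its lead over a second ring-bearing group, with a number 15.6 percentage points lower from compound 3 to compound 4 (beyond the scatter). On the carbonyl carbon, 3,5-dimethyl-1H-pyrazol-1-yl and (((4-methylphenyl)carbonyl)amino)amino cannot be told apart, with a number 0.6 percentage points lower from compound 2 to compound 4 (within the scatter), while 3,5-dimethyl-1H-pyrazol-1-yl stands far from benzylamino, with a number 37.2 percentage points higher from compound 1 to compound 4 (beyond the scatter), so a high number on a carbonyl-bearing chain is not tied to one group, though compound 1 shows that a carbonyl alone does not ensure it. Nothing measured here explains why these groups differ.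

The compounds shown leave open how a carboxylic acid or a simple amine-derived amide, such as a morpholine amide, would read on that carbonyl carbon. They also leave open whether a 1,3,4-oxadiazole carrying methyl in place of sulfanyl would stay level with compound 3.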